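A few compounds are considered here, and "the series" means these few. Any claim that something is new, unique, unknown or untested is made for them only; others in the source may bear on it.

Compound 1 `O=S(=O)(/C=C/c1ccc(Cl)cc1Cl)Cc1ccc(Nc2ncnc3ccccc23)cc1` gives 4000 nM in the first measurement.
Compound 2 `O=S(=O)(/C=C/c1ccc(F)cc1F)Cc1ccc(Nc2ncnc3ccccc23)cc1` gives > 100000 nM as a limit.

Among the measured compounds shown here, in a functional assay on MCF7 cells (Homo sapiens) (on this read-out higher numbers stand for weaker inhibition of growth and lower numbers for stronger inhibition of growth), compound 1 gives 4000 nM as the only exact number in this set. Compound 2 stands at > 100000 nM as a limit of the assay and not a number.

Compound 3 `O=S(=O)(/C=C/c1ccc(Cl)cc1Cl)Cc1ccc(Nc2ncnc3cc(Cl)ccc23)cc1` keeps the 2,4-dichlorophenyl of compound 1 and differs from it on the shared core (chloro in place of hydrogen on an aromatic carbon). For the measured compounds named here, the one measured step (an at least 25-fold higher number from compound 1 to compound 2 (1.39 log units; beyond the scatter)) was large, and its size rests on a limit (the limit of > 100000 nM in this assay, at which 1 of the 2 values shown sits). That step placed 2,4-difluorophenyl in place of 2,4-dichlorophenyl, so it is no direct guide to chloro in place of hydrogen on an aromatic carbon. Only a small step in this assay is therefore expected, with no firm direction and perhaps none beyond the scatter. The estimated step is modest (a 1.3-fold lower number from compound 1 to compound 3 (0.12 log units; within the scatter)). For compound 3 the expected value is 3000 nM with an estimated range from 800 nM to 15000 nM on repeated measurement.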

Compound 3, concentration for 50% growth inhibition: 25000 nM
For compound 3 the middle estimate is 8.3-fold (0.92 log units) below the measured one; the measured number lies above the stated range.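

In this assay, chloro in place of hydrogen on an aromatic carbon of the shared core gives a 6.3-fold higher number from compound 1 to compound 3 (0.80 log units; beyond the scatter) and so weaker inhibition of growth. This shows that the core position also bears on the read-out, not only the 2,4-dichlorophenyl that changed between compound 1 and compound 2, and that a single added chloro there moves the number beyond the scatter. Nothing measured here gives a reason for this change.

The compounds shown leave open whether a fluoro group, a methoxy group or an amine on the same aromatic carbon would raise the number as chloro does. They also leave open how this chloro would act alongside the 2,4-difluorophenyl of compound 2, which gives > 100000 nM as a limit and not a number.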